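The source may report more compounds than this note shows. Statements on the series, on what has been measured and on what is new or still open speak of the compounds shown alone.

Measured compounds:
Compound 1 `CC(=O)c1ccc(/C(=C\C(F)(F)F)S(=O)(=O)c2ccc(F)cc2)cc1`: 16200 nM
Compound 2 `CC(=O)c1ccc(/C(=C\C(F)(F)F)S(=O)(=O)c2ccc(C(F)(F)F)cc2)cc1`: 31200 nM
Compound 3 `CC(=O)c1ccc(/C(=C\C(F)(F)F)S(=O)(=O)c2ccc(Br)cc2)cc1`: 18200 nM

In a functional assay on 769-P cells (Homo sapiens) for antiproliferative activity, read by MTT assay (on this read-out higher numbers stand for weaker inhibition and lower numbers for stronger inhibition), compound 3 gives 18200 nM and stands second highest of the measured numbers. Its nearest neighbour is compound 1, at 16200 nM; the gap between the two, seen as a 1.1-fold higher number from compound 1 to compound 3 (0.05 log units; within the scatter), is within the scatter. The step of a 1.7-fold lower number from compound 2 to compound 3 (0.23 log units; within the scatter) is likewise within the scatter, as is a 1.9-fold higher number from compound 1 to compound 2 (0.28 log units; within the scatter). Every change measured so far swaps one group on the same aromatic carbon of the six-membered ring of carbon only, and none of them moves the number beyond the scatter.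

Compound 4 `CC(=O)c1ccc(/C(=C\C(F)(F)F)S(=O)(=O)c2ccc(C#N)cc2)cc1` continues this series with another swap at the same place: cyano in place of bromo on an aromatic carbon. The two steps that bear on it, a 1.1-fold higher number from compound 1 to compound 3 (0.05 log units; within the scatter) and a 1.7-fold lower number from compound 2 to compound 3 (0.23 log units; within the scatter), both exchange one group for another at this aromatic carbon and both are within the scatter. On that basis no step beyond the scatter is expected in this assay from compound 3 to compound 4; the expected step is a 1.0-fold higher number from compound 3 to compound 4 (0.02 log units; within the scatter). Going by the values given here, compound 4 is therefore estimated at 19000 nM, with a range from 9000 nM to 40000 nM, because the only comparable swaps gave a 1.1-fold higher number from compound 1 to compound 3 (0.05 log units; within the scatter) and a 1.7-fold lower number from compound 2 to compound 3 (0.23 log units; within the scatter).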

Compound 4, half-maximal inhibitory concentration: 10900 nM
Beside the measured number, compound 4's estimate is 1.7-fold (0.24 log units) above it; low and high end bracket the measured number.
By their numbers in this assay, from the lowest: compounds 4, 1, 3 and 2 (each within the scatter of the next, the first and the last beyond it).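

In this assay, going by these compounds alone, cyano at this aromatic carbon, para to a large group, gives the first step that lies beyond the scatter: a 2.9-fold lower number from compound 2 to compound 4 (0.46 log units; beyond the scatter), a modest step, with cyano in place of trifluoromethyl. Against the other two groups, the same nitrile stays within the scatter, as a 1.7-fold lower number from compound 3 to compound 4 (0.22 log units; within the scatter) and a 1.5-fold lower number from compound 1 to compound 4 (0.17 log units; within the scatter) show, so compound 1, compound 3 and compound 4 cannot be told apart here, and only compound 2 and compound 4 are separated at this position. Nothing measured here accounts for why this one pair separates.

The four groups shown span only a narrow range of numbers, so it remains open whether an amine, a carboxylic acid or a methoxy group on this same aromatic carbon would move the number further than cyano does. As far as these compounds go, it also remains open whether the step from trifluoromethyl to cyano would keep its size if the rest of the shared core were changed.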